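The source may hold more compounds than are shown below. What is called first, only, known or untested is meant among the compounds shown, and "the series" means these compounds.

Compound 1: `Cc1cc(OCc2ccc(Cl)cc2Cl)ccc1N1CCC[C@H]1CC(=O)O`, in a functional assay on cells for agonist activity at Free fatty acid receptor 1 (Homo sapiens), read by FLIPR and calcium flux, with a stated time of 100 s (a higher number here means that more compound is needed for the effect, a lower number that less compound is needed), compound 1 gives 8900 nM.
Compound 2: `Cc1ccccc1COc1ccc(N2CCC[C@H]2CC(=O)O)cc1`, in this assay compound 2 gives 190 nM.
Compound 3: `Cc1ccccc1COc1ccc(N2CCC[C@H]2CC(=O)O)cc1C`, in this assay compound 3 reaches only a limit of the assay, > 33000 nM.

Among the values that are numbers, compound 2 stands lowest in this assay, with compound 1 well above it. For the measured compounds named here, the only step measured in one place is an at least 170-fold higher number from compound 2 to compound 3 (2.23 log units; beyond the scatter), a methyl added on an aromatic carbon of the core; it is tied to the limit of > 33000 nM in this assay, at which 1 of the 3 values shown sits.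

Compound 4, `O=C(O)C[C@@H]1CCCN1c1ccc(Oc2ccc(Cl)cc2Cl)cc1`, arises from compound 2 by 2,4-dichlorophenyl in place of 2-methylbenzyl on an oxygen on an aromatic ring. Going by the values given here, no measured step addresses this exchange; compound 1 also carries a different group on that oxygen, but it differs from compound 2 in more than one respect, so its value alone cannot be attributed to the exchange. The direction of a 7.9-fold higher number from compound 2 to compound 4 (0.90 log units; beyond the scatter) is therefore expected with wide uncertainty. Compound 4 is estimated at 1500 nM, within 200 nM to 15000 nM.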

Compound 4, half-maximal effective concentration: 360 nM
Estimate against measurement, compound 4: 4.2-fold (0.62 log units) above, and the stated range covers the measured number.
By their numbers in this assay, from the lowest: compounds 2 and 4 (each within the scatter of the next); then compound 1. At a limit, above all of these: compound 3.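

For the compounds shown here, on the oxygen on an aromatic ring, the earlier compounds offered no single-place step, and the only such step lay on an aromatic carbon of the core. In this assay, 2,4-dichlorophenyl in place of 2-methylbenzyl now gives a 1.9-fold higher number from compound 2 to compound 4 (0.28 log units; within the scatter) and so leaves the read-out effectively unchanged, showing that this position accepts both groups. Nothing shown offers a reason for this result.

On these data alone, what an amine or an unsubstituted benzyl would give on that oxygen remains open. Also open, as far as these compounds go, is whether a methyl on the core would have the same effect with 2,4-dichlorophenyl in place.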